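The source may report more compounds than this note shows. Statements on the series, on what has been measured and on what is new or still open speak of the compounds shown alone.

- compound 1 (`O=C(CSc1nnc(-c2ccccc2F)o1)c1ccccc1`): 260 nM
- compound 2 (`Cc1ccc(-c2nnc(SCC(=O)c3ccc(Br)cc3)o2)c(O)c1`): 2070 nM
- compound 3 (`O=C(CSc1nnc(-c2ccccc2F)o1)c1ccc(Br)cc1`): 240 nM

In a functional assay on MCF7 cells (Homo sapiens) for cytotoxicity, read by MTT assay and propidium iodide staining, with a stated time of 24 h (on this read-out higher numbers stand for weaker inhibition and lower numbers for stronger inhibition), compound 3 shares the low end of these numbers with compound 1, while compound 2 stands well apart. Compound 4 (`COc1ccccc1-c1nnc(SCC(=O)c2ccc(Br)cc2)o1`) carries methoxy in place of fluoro on an aromatic carbon, ortho to a large group (methoxy in place of fluoro on an aromatic carbon). The bromo swap gave little (a 1.1-fold lower number from compound 1 to compound 3 (0.03 log units; within the scatter)) and involves a different group. The closer guide also removes 2-fluorophenyl, and it gave a clear rise (an 8.6-fold lower number from compound 2 to compound 3 (0.94 log units; beyond the scatter), read in reverse). That is a single example, so the evidence is thin. A smaller rise is expected here (a 2.5-fold higher number from compound 3 to compound 4 (0.40 log units; beyond the scatter)). For compound 4 the estimated value is 600 nM (expected range 200 nM to 2000 nM).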

Compound 4, half-maximal inhibitory concentration: 600 nM
Estimate against measurement, compound 4: no gap at the digits printed; low and high end bracket the measured number.
By their numbers in this assay, from the lowest: compounds 3 and 1 (each within the scatter of the next); then compound 4; then compound 2.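

In this assay the swap from fluoro to methoxy on this aromatic carbon gives a 2.5-fold higher number from compound 3 to compound 4 (0.40 log units; beyond the scatter) and so shows that changing this one substituent is enough to shift the number beyond the scatter. Replacing 2-hydroxy-4-methylphenyl with 2-methoxyphenyl gives a 3.5-fold lower number from compound 2 to compound 4 (0.54 log units; beyond the scatter) and places 2-methoxyphenyl between the other two groups in this series. Nothing measured here explains this order.

The compounds shown leave open how an amine or a longer chain such as ethoxy would fare at this place. They also leave open whether fluoro to methoxy would give a similar step with hydrogen in place of bromo.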